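A Selenium-Bearing Group Takes the Place of Chlorine

The source may report more compounds than this note shows. Statements on the series, on what has been measured and on what is new or still open speak of the compounds shown alone.

Of the compounds shown here, three sharing one core have been measured in a functional assay on MGC-803 cells (Homo sapiens) for inhibition, read by MTT assay, with a stated time of 48 h; on this read-out lower numbers stand for stronger inhibition and higher numbers for weaker inhibition. There, compound 1 `CCCCC(=O)N(Cc1ccc(OC)c(O)c1)c1cc(OC)c(OC)c(OC)c1` gives 66 nM, compound 2 `CC/C=C/C(=O)N(Cc1ccc(OC)c(O)c1)c1cc(OC)c(OC)c(OC)c1` gives 58 nM and compound 3 `COc1ccc(CN(C(=O)CCl)c2cc(OC)c(OC)c(OC)c2)cc1O` gives 84 nM. Compound 3 therefore stands within the scatter of both others, as shown by a 1.3-fold higher number from compound 1 to compound 3 (0.10 log units; within the scatter) and a 1.4-fold higher number from compound 2 to compound 3 (0.16 log units; within the scatter). The remaining pair also stays within the scatter, at a 1.1-fold lower number from compound 1 to compound 2 (0.06 log units; within the scatter).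

Compound 4 `COc1ccc(CN(C(=O)C[Se]C#N)c2cc(OC)c(OC)c(OC)c2)cc1O` keeps the core of compound 3 and differs in one place: a group of 3 heavy atoms (1 carbon, 1 nitrogen, 1 selenium; no ring) in place of one chlorine atom, on a saturated chain carbon bound to a carbonyl carbon. The change lies on a saturated chain carbon bound to a carbonyl carbon. The closest evidence is a 1.3-fold higher number from compound 1 to compound 3 (0.10 log units; within the scatter), which exchanges chloro for propyl at that same place. The other two steps alter the whole group on the carbonyl carbon, and neither leaves the scatter. From the compounds shown here alone, these three compounds therefore show little response in this assay to changes here, although none of them contains selenium, so the new group itself remains untested. No step beyond the scatter is expected, and the expected change is a 1.4-fold lower number from compound 3 to compound 4 (0.15 log units; within the scatter). For compound 4 the estimated value is 60 nM. The expected range for compound 4 runs from 20 nM to 170 nM, kept wide for the untested group.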

Compound 4, half-maximal inhibitory concentration: 270 nM
For compound 4 the middle estimate is 4.5-fold (0.65 log units) below the measured one, and the stated range ends below it.
By their numbers in this assay, from the lowest: compounds 2, 1 and 3 (each within the scatter of the next); then compound 4.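

In this assay this position proves responsive after all: the group of 3 heavy atoms (1 carbon, 1 nitrogen, 1 selenium) gives a 3.2-fold higher number from compound 3 to compound 4 (0.51 log units; beyond the scatter), a step beyond the scatter, whereas the exchange of chloro for propyl at the same place stayed within it. The comparisons with the other two compounds point the same way, with a 4.1-fold higher number from compound 1 to compound 4 (0.61 log units; beyond the scatter) where the selenium-bearing group stands in place of the propyl part and a 4.7-fold higher number from compound 2 to compound 4 (0.67 log units; beyond the scatter) where the whole group on the carbonyl carbon differs, so that compound 4 alone stands apart, on the side of weaker inhibition, from the three earlier compounds, which remain within the scatter of one another. The data shown hold nothing that accounts for this loss, so the step stands as an observation without an explanation.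

Whether the step belongs to the selenium atom or to the nitrile it carries stays open, as a thiocyanate, with sulfur in place of selenium, is not among these compounds. A methylseleno group or an amine on the same saturated chain carbon would be needed to separate these parts of the change.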